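This account rests on a few compounds, and the source may have more. Where it says the series, first, only, none or still open, it means among the compounds named here.

Of the compounds shown here, two from this series have been tested in a functional assay on PC-3 cells (Homo sapiens) for antiproliferative activity, read by MTT assay, with a stated time of 72 h; a higher number here means a weaker inhibitor, a lower number a stronger inhibitor. Compound 1 `COc1cc2ncnc(N3CCc4ccccc43)c2cc1NC(=O)/C=C/CN1CCN(C)CC1` gives 9180 nM. Compound 2 `CCN(CC)C/C=C/C(=O)Nc1cc2c(N3CCCc4ccccc43)ncnc2cc1OC` gives 6890 nM, the lower of the two numbers, yet the gap to compound 1 lies within the usual scatter of repeated measurements, so the two values are best read as matching. Compound 1 and compound 2 differ in two places at once, so no single change can be read from their pair.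

Compound 3 `COc1cc2ncnc(N3CCCc4ccccc43)c2cc1NC(=O)/C=C/CN1CCN(C)CC1` keeps the core of compound 2 and carries 4-methylpiperazin-1-yl in place of diethylamino on a saturated chain carbon bound to a double-bonded chain carbon. Among the compounds with values here, no measured pair isolates this exchange. Within the data shown here, the only hint comes from compound 1, whose 9180 nM shows that the 4-methylpiperazin-1-yl end group, on a different core, sits in the same range as the diethylamino end group of compound 2. On that basis the step is expected to stay inside the scatter, leaning if anything towards a slightly higher number, as a 1.2-fold higher number from compound 2 to compound 3 (0.09 log units; within the scatter). Compound 3 is therefore estimated at 8500 nM in this assay, with a plausible range from 3500 nM to 20000 nM.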

Compound 3, half-maximal inhibitory concentration: 6260 nM
Compound 3: middle estimate off by 1.4-fold (0.13 log units), on the high side; the range from low to high includes it.
By their numbers in this assay, from the lowest: compounds 3, 2 and 1 (each within the scatter of the next).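

In this assay, exchanging diethylamino for 4-methylpiperazin-1-yl on a saturated chain carbon bound to a double-bonded chain carbon, with the core held constant, gives a 1.1-fold lower number from compound 2 to compound 3 (0.04 log units; within the scatter), so the added ring and second nitrogen leave the antiproliferative read-out indistinguishable from that of the open-chain amine. Compound 3 also supplies a second clean pair: with the end group held constant, 1,2,3,4-tetrahydroquinolin-1-yl in place of 2,3-dihydro-1H-indol-1-yl on an aromatic carbon gives a 1.5-fold lower number from compound 1 to compound 3 (0.17 log units; within the scatter), and this exchange likewise cannot be told apart from repeat-measurement noise. Thus the two changes mixed together in compounds 1 and 2 can now be read one at a time, and neither separates its pair, though no measurement bears on why.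

Going by these compounds, whether the end group matters at all remains open, since two amines cannot show what a morpholin-4-yl group, a dimethylamino group or a carboxylic acid would do at the same place. On these data alone, it also remains open whether the diethylamino group would match 4-methylpiperazin-1-yl on the core of compound 1 as it does on the core of compound 3.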